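Pyrrole for Quinoline on the Amide Carbonyl

A few compounds are considered here, and "the series" means these few. Any claim that something is new, unique, unknown or untested is made for them only; others in the source may bear on it.

In a functional assay on MCF7 cells (Homo sapiens) for antiproliferative activity, read by MTT assay, with a stated time of 72 h (on this read-out higher numbers stand for weaker inhibition and lower numbers for stronger inhibition), compound 3 `CCN1CCN(c2cc(C)c3cc(NC(=O)c4ccc5ccccc5n4)ccc3n2)CC1` gives 7060 nM, the second highest of the three numbers: compound 2 `Cc1cc(N(C)C)nc2ccc(NC(=O)c3ccc(Cl)c(Cl)c3)cc12` gives 33300 nM, while compound 1 `CCN(CC)CCNc1cc(C)c2cc(NC(=O)c3ccc(Cl)c(Cl)c3)ccc2n1` gives 1420 nM. Within the data shown here, the only measured step, a 23-fold higher number from compound 1 to compound 2 (1.37 log units; beyond the scatter), concerns an exchange on an aromatic carbon and says nothing about the amide side of the core. Compound 4 `CCN1CCN(c2cc(C)c3cc(NC(=O)c4ccc[nH]4)ccc3n2)CC1` differs from compound 3 by 1H-pyrrol-2-yl in place of quinolin-2-yl on a carbonyl carbon. Among the measured compounds shown here, no measured pair bears on this exchange, so the expected step is a 1.3-fold higher number from compound 3 to compound 4 (0.11 log units; within the scatter), not beyond the usual scatter in either direction. The estimate for compound 4 is therefore 9000 nM, within a range of 2500 nM to 32000 nM, with wide uncertainty because no shown step tests the amide aryl group.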

Compound 4, half-maximal inhibitory concentration: 14700 nM
For compound 4 the middle estimate is 1.6-fold (0.21 log units) below the measured one; measured number inside the range.
By their numbers in this assay, from the lowest: compound 1; then compound 3; then compound 4; then compound 2.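

In this assay, among these compounds, the exchange of quinolin-2-yl for 1H-pyrrol-2-yl on a carbonyl carbon gives a 2.1-fold higher number from compound 3 to compound 4 (0.32 log units; beyond the scatter) and so provides the one measured step on the amide side of the shared core. The step is modest, but it shows that the number responds to this position, though ring size, hydrogen-bond donor and hydrogen-bond acceptor all change together and cannot be told apart here. Nothing measured explains the step. Open, as far as these compounds go, is how a phenyl or a pyridin-3-yl group would fall on this carbonyl carbon, and whether the same exchange would give a similar step on the core of compound 1.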